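Undrawn stereocentres: from compound 2 to compound 3

A few compounds are considered here, and "the series" means these few. Any claim that something is new, unique, unknown or untested is made for them only; others in the source may bear on it.

Measured compounds:
compound 1 `CC(C)CC(=O)[C@@H]1O[C@@]12C(=O)C=C(Cc1ccccc1)NC2=O`: > 50000 nM
compound 2 `CC1=CC(=O)[C@@]2(O[C@H]2C(=O)CC(C)C)C(=O)N1`: "not determined" (no result reported)

In an ADME assay on MRC5 cells (Homo sapiens) for cytotoxicity, read by WST assay, with a stated time of 48 h (a higher number here means a weaker inhibitor, a lower number a stronger inhibitor), compound 1 reaches only a limit, > 50000 nM, as the limit of > 50000 nM in this assay, at which 1 of the 2 values shown sits, records. Compound 2 has no number at all in this assay, its result being "not determined" (no result reported). Compound 3 `CC1=CC(=O)C2(OC2C(=O)CC(C)C)C(=O)N1` differs from compound 2 as follows: the two compounds have the same atoms and bonds; at least one stereo element is drawn with a configuration in one of them and without one in the other: 2 of 2 stereo elements differ; a stereocentre at a saturated ring carbon is drawn R in compound 2 and without a configuration in compound 3; a stereocentre at a saturated ring carbon is drawn R in compound 2 and without a configuration in compound 3. Since nothing leaves and nothing enters, no step beyond the scatter is expected in this assay in either direction. Compound 3 is therefore expected to sit at about 50000 nM in this assay, most likely again as a limit, within 20000 nM to 100000 nM.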

Compound 3, half-maximal inhibitory concentration: 33200 nM
The estimate for compound 3 lay 1.5-fold (0.18 log units) above the measured number, and the stated range covers the measured number.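

Within the data shown here, compound 2 has no number in this assay, and no step to compound 3, at 33200 nM, can be read. The compounds shown leave open whether the drawn configuration at the two stereocentres bears on the result in this assay.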